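A few compounds are considered here, and "the series" means these few. Any claim that something is new, unique, unknown or untested is made for them only; others in the source may bear on it.

Compound 1 `O=C(NCc1ccc(S(=O)(=O)c2ccccc2)cc1)c1cc2ccncc2s1` gives 14 nM in a functional assay on A2780 cells (Homo sapiens) for inhibition, read by sulforhodamine B assay, with a stated time of 72 h; a higher number here means a weaker inhibitor, a lower number a stronger inhibitor. Compound 2 `O=C(NCc1ccc(S(=O)(=O)c2ccccc2)cc1)c1ccc2nncn2c1` sits at the limit > 10000 nM in this assay, which is not a number. Within the data shown here, the step of an at least 710-fold higher number from compound 1 to compound 2 (2.85 log units; beyond the scatter) is the only measured step, and it concerns the group on the carbonyl carbon. Compound 3 `O=C(NCc1ccc(S(=O)(=O)N2CCCCC2)cc1)c1cnc2nccn2c1` gives 130 nM in this assay, the higher of the two numbers given, with compound 1 giving the lower one. Compound 4 `O=C(NCc1ccc(S(=O)(=O)c2ccccc2)cc1)c1cnc2nccn2c1` differs from compound 3 by phenyl in place of piperidin-1-yl on a sulfonyl sulfur. Among the measured compounds shown here, no measured step concerns the group on the sulfonyl sulfur. A modest step is expected, because compound 1 gives 14 nM while carrying phenylsulfonyl on a different core. Compound 4 is expected to show a 1.6-fold lower number from compound 3 to compound 4 (0.21 log units; within the scatter). The estimate for compound 4 is 80 nM, expected to lie between 20 nM and 300 nM.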

Compound 4, half-maximal inhibitory concentration: 68 nM
Beside the measured number, compound 4's estimate is 1.2-fold (0.07 log units) above it, within the range that was stated.
By their numbers in this assay, from the lowest: compound 1; then compounds 4 and 3 (each within the scatter of the next). At a limit, above all of these: compound 2.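

Among these compounds, the first look at the group on the sulfonyl sulfur gives a 1.9-fold lower number from compound 3 to compound 4 (0.28 log units; within the scatter), so phenyl and piperidin-1-yl cannot be told apart in this assay. With phenylsulfonyl kept, the group on the carbonyl carbon does count: a 4.9-fold higher number from compound 1 to compound 4 (0.69 log units; beyond the scatter). Compound 2 stands at a limit, not a number, and its step reads an at least 140-fold lower number from compound 2 to compound 4 (2.16 log units; beyond the scatter), although both groups hold the same count of carbon and nitrogen atoms.

From the compounds shown here alone, whether an amine or a longer chain on the sulfonyl sulfur would behave like phenyl stays open. So does whether the core of compound 1 keeps its lower number with piperidin-1-yl.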